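The source may hold more compounds than are shown below. What is called first, only, known or untested is meant among the compounds shown, and "the series" means these compounds.

Measured compounds in a functional assay on BGC-823 cells (Homo sapiens) for cytotoxicity, read by MTT assay, with a stated time of 48 h; on this read-out lower numbers stand for stronger inhibition and higher numbers for weaker inhibition:

compound 1 `O=C(CSc1nnc(-c2ccncc2)o1)N/N=C/c1ccccc1F` gives 24000 nM
compound 2 `O=C(CSc1nnc(-c2ccncc2)o1)N/N=C/c1ccccc1[N+](=O)[O-]` gives 41600 nM
compound 3 `O=C(CSc1nnc(-c2ccncc2)o1)N/N=C/c1cc(Cl)ccc1O` gives 5470 nM

Compound 3 holds the lowest number of the three in this assay. The step of a 4.4-fold lower number from compound 1 to compound 3 (0.64 log units; beyond the scatter) and the step of a 7.6-fold lower number from compound 2 to compound 3 (0.88 log units; beyond the scatter) both lie beyond the scatter, while a 1.7-fold higher number from compound 1 to compound 2 (0.24 log units; within the scatter) stays within it, so on these numbers the 5-chloro-2-hydroxyphenyl group sets compound 3 apart from the other two aryl groups.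

Compound 4 `O=C(CSc1nnc(-c2ccncc2)o1)N/N=C/C=C/c1ccccc1` has not been measured. Relative to compound 3 the change is 2-phenylethenyl in place of 5-chloro-2-hydroxyphenyl on a carbon with a double bond to nitrogen. Among the compounds with values here, the change removes exactly the group whose introduction carried the steps from compound 1 and compound 2 to compound 3, and the incoming 2-phenylethenyl group has no close counterpart among the measured compounds. The expectation is therefore a move back toward the numbers of compound 1 and compound 2, of about the size of a 4.4-fold lower number from compound 1 to compound 3 (0.64 log units; beyond the scatter) reversed, meaning a step of a 2.9-fold higher number from compound 3 to compound 4 (0.47 log units; beyond the scatter) is expected in this assay. Compound 4 is accordingly estimated at 16000 nM, with a range from 5000 nM to 50000 nM.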

Compound 4, half-maximal inhibitory concentration: 10600 nM
Compound 4: the middle estimate sits 1.5-fold (0.18 log units) above what was measured, and the stated range covers the measured number.
By their numbers in this assay, from the lowest: compounds 3 and 4 (each within the scatter of the next); then compounds 1 and 2 (each within the scatter of the next).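

In this assay the carbon with a double bond to nitrogen takes 2-phenylethenyl in place of 5-chloro-2-hydroxyphenyl with only a 1.9-fold higher number from compound 3 to compound 4 (0.29 log units; within the scatter), so an entering group of carbon alone, with 0 hydrogen-bond donors and 0 hydrogen-bond acceptors, stays within the scatter of compound 3. The separation from the other aryl groups is therefore not unique to 5-chloro-2-hydroxyphenyl, as the series also shows a 3.9-fold lower number from compound 2 to compound 4 (0.59 log units; beyond the scatter) and a 2.3-fold lower number from compound 1 to compound 4 (0.35 log units; beyond the scatter). No supporting measurement is available to explain these steps.

The compounds shown leave open whether the double bond outside the aromatic ring matters, which a saturated 2-phenylethyl group would test. From the compounds shown here alone, how a 2-hydroxyphenyl group without the chlorine would compare also remains open.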